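Removing the Acid from a Pyrrolidine Side Chain

This account rests on a few compounds, and the source may have more. Where it says the series, first, only, none or still open, it means among the compounds named here.

Compound 1 `COc1ccc(/C=C\c2cc(OC)c(OC)c(OC)c2)cc1OCc1ccc(C=O)cc1` carries a formyl group on the outer aromatic ring, and in a functional assay on HepG2 cells (Homo sapiens) for antiproliferative activity, read by CCK-8 assay, with a stated time of 48 h (a lower number here means a stronger inhibitor, a higher number a weaker inhibitor), compound 1 gives 800 nM. Compound 2 `COc1ccc(/C=C\c2cc(OC)c(OC)c(OC)c2)cc1OCc1ccc(CN2C[C@H](O)C[C@@H]2C(=O)O)cc1` has a (2-carboxy-4-hydroxypyrrolidin-1-yl)methyl group in place of that formyl group. In this assay compound 2 reaches only the limit of > 10000 nM, which is a limit of the assay and not a measured number. The change amounts to an at least 12-fold higher number from compound 1 to compound 2 (1.09 log units; beyond the scatter). Compound 2 therefore stands at the weak end of what has been measured so far, sitting at the limit of > 10000 nM in this assay, at which 1 of the 2 values shown sits.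

Compound 3 `COc1ccc(/C=C\c2cc(OC)c(OC)c(OC)c2)cc1OCc1ccc(CN2CC[C@H](O)C2)cc1` keeps everything else and makes the change (3-hydroxypyrrolidin-1-yl in place of 2-carboxy-4-hydroxypyrrolidin-1-yl on a saturated chain carbon bound to an aromatic carbon). Among the compounds with values here, the only measured step that bears on this is the one from compound 1 to compound 2, which was large and went toward weaker inhibition when the acid-bearing ring entered. Compound 3 keeps that ring but loses the carboxylic acid, so part of the loss is expected to reverse, and the estimated step is an at least 4.0-fold lower number from compound 2 to compound 3 (0.60 log units; beyond the scatter). For compound 3 the expected result in this assay is 2500 nM, with a range from 400 nM to 12000 nM.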

Compound 3, half-maximal inhibitory concentration: 6600 nM
Compound 3: middle estimate off by 2.6-fold (0.42 log units), on the low side; the measured number falls inside the stated range.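

Within the data shown here, compound 3 gives the first exact number for a pyrrolidine side chain in this assay, and it shows that the loss of activity does not depend on a carboxylic acid being present: swapping the formyl group for the acid-free (3-hydroxypyrrolidin-1-yl)methyl group still gives an 8.3-fold higher number from compound 1 to compound 3 (0.92 log units; beyond the scatter). Removing the acid from the side chain gives an at least 1.5-fold lower number from compound 2 to compound 3 (0.18 log units; that floor lies within the scatter), and since that floor lies within the scatter, the data cannot say whether the acid itself weakens the compound or by how much. The true size of this step stays unknown, as compound 2 has only a limit of the assay and not a measured number: the limit of > 10000 nM in this assay, at which 1 of the 3 values shown sits.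

The compounds shown leave open which part of the side chain carries the loss relative to compound 1, and a plain pyrrolidin-1-ylmethyl group without the hydroxyl, or a morpholine ring in its place, would help to separate the hydroxyl from the ring nitrogen. A methyl ester in place of the carboxylic acid on the ring of compound 2 would likewise test the acid more directly.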